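Halogen placement on the anilide ring and growth inhibition

The source may report more compounds than this note shows. Statements on the series, on what has been measured and on what is new or still open speak of the compounds shown alone.

Measured compounds:
compound 1, `CN(C)C(=O)c1cc2cnc(Nc3ccc(NC(=O)C4(C(=O)Nc5ccc(Br)cc5)CC4)cc3)nc2n1C1CCCC1`, 13.7%
compound 2, `CN(C)C(=O)c1cc2cnc(Nc3ccc(NC(=O)C4(C(=O)Nc5ccc(Cl)c(C(F)(F)F)c5)CC4)cc3)nc2n1C1CCCC1`, -2.4%
compound 3, `CN(C)C(=O)c1cc2cnc(Nc3ccc(NC(=O)C4(C(=O)Nc5cccc(Cl)c5)CC4)cc3)nc2n1C1CCCC1`, 15.5%

Of the three measured compounds, compound 3 gives the highest number in a functional assay on OVCAR-5 cells (Homo sapiens) for inhibition, read by CCK-8 assay, with a stated time of 72 h, tested at 1 uM (on this read-out lower numbers stand for less inhibition of growth and higher numbers for more inhibition of growth at the one concentration tested), but its lead over compound 1 is within the scatter, whereas a number 17.9 percentage points higher from compound 2 to compound 3 (beyond the scatter) is a step beyond it. The unmeasured compound 4, `CN(C)C(=O)c1cc2cnc(Nc3ccc(NC(=O)C4(C(=O)Nc5ccc(Cl)cc5)CC4)cc3)nc2n1C1CCCC1`, differs from compound 3 only in this respect: 4-chlorophenyl in place of 3-chlorophenyl on an amide-type nitrogen. Going by the values given here, no measured step makes exactly this change. The closest is a number 1.8 percentage points higher from compound 1 to compound 3 (within the scatter), which also moves a halogen on the same ring without leaving the scatter. Among the compounds with values here, the one step that clearly lowered the read-out, a number 16.1 percentage points lower from compound 1 to compound 2 (beyond the scatter), also introduced the trifluoromethyl group and so does not directly bear on compound 4. Compound 4 is therefore expected to sit near compounds 1 and 3, with a step of about a number 1.5 percentage points lower from compound 3 to compound 4 (within the scatter), within the scatter. The estimate for compound 4 in this assay is 14%, with a range from 2% to 26%.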

Compound 4, percent growth inhibition at one concentration: 8.1%
For compound 4 the middle estimate is 5.9 percentage points above the measured one; the range from low to high includes it.
By their numbers in this assay, from the lowest: compound 2; then compounds 4, 1 and 3 (each within the scatter of the next).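

In this assay, shifting the chlorine from the 3-chlorophenyl of compound 3 to the 4-chlorophenyl of compound 4 gives a number 7.4 percentage points lower from compound 3 to compound 4 (within the scatter), so the chlorine's place on this ring cannot be told apart here, and chloro in place of bromo on an aromatic carbon, at a number 5.6 percentage points lower from compound 1 to compound 4 (within the scatter), is equally unresolved. Going by these compounds alone, the trifluoromethyl group can now be read as a single change: hydrogen in its place on an aromatic carbon gives a number 10.5 percentage points higher from compound 2 to compound 4 (beyond the scatter), whereas the earlier steps from compound 2 also differed in the halogen's identity or position. No measurement at hand accounts for these differences.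

As far as these compounds go, whether a methoxy group, a nitrile or an amine on this ring would shift growth inhibition remains open. So does whether fluoro would behave as chloro and bromo do.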